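The source may hold more compounds than are shown below. What is called first, only, known or untested is meant among the compounds shown, and "the series" means these compounds.

Working notes on the series. The shared core carries a thiosemicarbazone arm ending in an aryl group. Compound 1 `CC1=CC[C@H](C(C)(C)NC(=S)N/N=C/c2ccccc2)CC1` gives 31600 nM in a functional assay on UACC-62 cells (Homo sapiens) for inhibition, read by sulforhodamine B assay, with a stated time of 48 h; on this read-out lower numbers stand for stronger inhibition of growth and higher numbers for weaker inhibition of growth. Compound 2 `CC1=CC[C@H](C(C)(C)NC(=S)N/N=C/c2ccc(O)cc2)CC1` reaches only a limit of this assay, > 100000 nM. Compound 3 `CC1=CC[C@H](C(C)(C)NC(=S)N/N=C/c2ccccc2O)CC1` gives 2800 nM, the lowest of the two numbers, with compound 1 as nearest neighbour. The step of an 11-fold lower number from compound 1 to compound 3 (1.05 log units; beyond the scatter) is large, whereas an at least 3.1-fold higher number from compound 1 to compound 2 (0.50 log units; beyond the scatter) runs the other way, and an at least 35-fold lower number from compound 2 to compound 3 (1.55 log units; beyond the scatter) sums the two. Compound 4 `CC1=CC[C@H](C(C)(C)NC(=S)N/N=C/c2ccccc2[N+](=O)[O-])CC1` differs from compound 3 by nitro in place of hydroxy on an aromatic carbon. Within the data shown here, no measured step involves a nitro group; the only bearing comes from an 11-fold lower number from compound 1 to compound 3 (1.05 log units; beyond the scatter), read backwards as loss of the hydroxy. The number for compound 4 is therefore expected to rise toward compound 1, estimated at 15000 nM (4000 nM to 60000 nM), a step of a 5.4-fold higher number from compound 3 to compound 4 (0.73 log units; beyond the scatter).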

Compound 4, concentration for 50% growth inhibition: 10600 nM
Estimate against measurement, compound 4: 1.4-fold (0.15 log units) above; low and high end bracket the measured number.
By their numbers in this assay, from the lowest: compound 3; then compound 4; then compound 1. At a limit, above all of these: compound 2.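

Nitro on an aromatic carbon ortho to a large group also beats hydrogen, with a 3.0-fold lower number from compound 1 to compound 4 (0.47 log units; beyond the scatter) as the step, so the gain at this place is not confined to hydroxy. Nitro enters with 0 hydrogen-bond donors, so a donor here is not needed for a lower number than that of compound 1, yet a 3.8-fold higher number from compound 3 to compound 4 (0.58 log units; beyond the scatter) still leaves hydroxy ahead of nitro. On these data alone, whether an amine or a methoxy group at this place would fall nearer compound 3 or compound 4 stays open. Nothing shown here gives a cause for the gap between hydroxy and nitro.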